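Fluoro for trifluoromethyl on two cores

The source may report more compounds than this note shows. Statements on the series, on what has been measured and on what is new or still open speak of the compounds shown alone.

Activity is read in a functional assay on SW480 cells (Homo sapiens) for cytotoxicity, read by MTT assay, with a stated time of 4 days; on this read-out lower numbers stand for stronger inhibition and higher numbers for weaker inhibition. Compound 2 `C=C1C[C@]23C[C@@]1(O)CC[C@H]2c1cc(Br)c(O)c(C)c1[C@@H]3Cn1cc(-c2ccc(C(F)(F)F)cc2)nn1` gives 15200 nM in this assay. Compound 1 `C=C1C[C@]23C[C@@]1(O)CC[C@H]2c1cc(Br)c(O)c(C)c1[C@@H]3Cn1cc(-c2ccc(F)cc2)nn1` differs from compound 2 by fluoro in place of trifluoromethyl on an aromatic carbon. In this assay compound 1 returns only a limit of the assay, > 20000 nM. The step of an at least 1.3-fold higher number from compound 2 to compound 1 (0.11 log units; that floor lies within the scatter) is thus known only as a floor, and two of the three values sit at the limit of > 20000 nM in this assay, at which 2 of the 3 values shown sit.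

Compound 3 `Cc1ccc(S(=O)(=O)Oc2ccc3c(c2C)[C@H](Cn2cc(-c4ccc(C(F)(F)F)cc4)nn2)[C@@]24CC(=O)[C@@](C)(CC[C@@H]32)C4)cc1` rests on a different core; how the core of compound 3 differs from that of compound 2 is not broken down here. In this assay compound 3 reports only a limit, > 20000 nM.

Compound 4 `Cc1ccc(S(=O)(=O)Oc2ccc3c(c2C)[C@H](Cn2cc(-c4ccc(F)cc4)nn2)[C@@]24CC(=O)[C@@](C)(CC[C@@H]32)C4)cc1` is the not yet measured partner of compound 3 and differs from it by fluoro in place of trifluoromethyl on an aromatic carbon, the same structural change that separates compound 2 and compound 1, at the same place. For compound 4 a step that the limit leaves unreadable from compound 3 to compound 4 is expected, resting on the like change having given an at least 1.3-fold higher number from compound 2 to compound 1 (0.11 log units; that floor lies within the scatter). Compound 4 is therefore estimated at 35000 nM, between 15000 nM and 90000 nM, most likely reported again only as a limit.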

Compound 4, half-maximal inhibitory concentration: > 20000 nM
Compound 4: a limit, no number (the forecaster's own chance of this, stated with the estimate: 85%); the middle value lies beyond the limit too.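

Compound 3 and compound 4 both return only a limit in this assay, and the step between them cannot be read: the limit of > 20000 nM in this assay, at which 3 of the 4 values shown sit.

The compounds shown leave open whether fluoro in place of trifluoromethyl changes activity on either core, and how far past the limit compound 1, compound 3 and compound 4 lie.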